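A few compounds are considered here, and "the series" means these few. Any claim that something is new, unique, unknown or untested is made for them only; others in the source may bear on it.

In a functional assay on K562 cells (Homo sapiens) for antiproliferative activity, read by MTT assay, with a stated time of 48 h (a lower number here means a stronger inhibitor, a higher number a weaker inhibitor), compound 3 `CN(C)CCCn1c(N)c(-c2nc3ccccc3n2C)c2nc(C#N)c(C#N)nc21` gives 3560 nM. Compound 1 `CCN(CC)CCCCn1c(N)c(-c2nc3ccccc3[nH]2)c2nc(C#N)c(C#N)nc21` gives 1440 nM, a lower number than that of compound 3, with a gap beyond the scatter. Compound 2 `CCN(CC)CCn1c(N)c(-c2nc3ccccc3n2C)c2nc(C#N)c(C#N)nc21` reads > 50000 nM, which is a limit of the assay and not a number. For the measured compounds named here, compound 3 therefore has the higher of the two true numbers so far.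

The next compound is compound 4 `CCN(CC)CCCCn1c(N)c(-c2nc3ccccc3n2C)c2nc(C#N)c(C#N)nc21`, and the change is (diethylamino)methyl in place of dimethylamino on a saturated chain carbon, three bonds along the chain from an aromatic nitrogen. Cut one bond further out, this reads 3-(dimethylamino)propyl to 4-(diethylamino)butyl.

Going by the values given here, one measured step bears directly on this part of the molecule: an at least 14-fold lower number from compound 2 to compound 3 (1.14 log units; beyond the scatter). That step was large and beyond the scatter, so changes in this chain can matter a great deal, although it starts from a limit and gives no exact size. A second clue comes from compound 1, which also carries the 4-(diethylamino)butyl chain and gives 1440 nM. Compound 4 is thus expected to stay in the low micromolar region rather than fall off as compound 2 does. The expected change is a 1.4-fold lower number from compound 3 to compound 4 (0.15 log units; within the scatter), a slight move towards a lower number that is not expected to exceed the scatter. For compound 4 the estimated value is 2500 nM, with an expected range from 800 nM to 9000 nM.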

Compound 4, half-maximal inhibitory concentration: 1010 nM
Beside the measured number, compound 4's estimate is 2.5-fold (0.39 log units) above it; the measured number falls inside the stated range.
By their numbers in this assay, from the lowest: compounds 4 and 1 (each within the scatter of the next); then compound 3. At a limit, above all of these: compound 2.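

In this assay, for the compounds shown here, moving from the 3-(dimethylamino)propyl chain to the 4-(diethylamino)butyl chain gives a 3.5-fold lower number from compound 3 to compound 4 (0.55 log units; beyond the scatter), so with the methyl kept on the aromatic nitrogen, this change gives a real, modest gain that the earlier compounds could not show. With the diethylamino group kept and only the length of the chain changed, the result is an at least 49-fold lower number from compound 2 to compound 4 (1.69 log units; beyond the scatter), which shows that chain length alone can separate a compound in the low micromolar region from one with no exact reading, although this step starts from a limit of the assay and gives only a minimum size: the limit of > 50000 nM in this assay, at which 1 of the 4 values shown sits. Methyl in place of hydrogen on an aromatic nitrogen gives a 1.4-fold lower number from compound 1 to compound 4 (0.15 log units; within the scatter), so with the 4-(diethylamino)butyl chain in place this methyl makes no difference that can be told from the scatter.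

The step from compound 3 changes the chain length and the alkyl groups on the amine together, so the compounds shown do not divide the gain between these two changes. A 4-(dimethylamino)butyl chain or a 3-(diethylamino)propyl chain would separate them, and a still longer chain or a piperidine at the chain end remains an open question.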